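The source may hold more compounds than are shown below. What is called first, only, known or untested is meant among the compounds shown, and "the series" means these compounds.

Within this set, compound 3 `CC(C)=CCN(C)C1CCN(CCCc2c[nH]c3ccc(-n4cnnc4)cc23)CC1` gives the lowest number in an assay on CHO cells for displacement of a labelled ligand from 5-hydroxytryptamine receptor 1D (Homo sapiens) (on this read-out higher numbers stand for weaker inhibition and lower numbers for stronger inhibition), at 0.5 nM; compound 2 `CC(=O)Nc1ccc([C@@H](C)NCC2CCN(CCCc3c[nH]c4ccc(-n5cnnc5)cc34)CC2)cc1` gives 1.5 nM and compound 1 `CN(Cc1cccs1)C1CCN(CCCc2c[nH]c3ccc(-n4cnnc4)cc23)CC1` gives 4.3 nM. Compound 4 `c1ccc(NCC2CCN(CCCc3c[nH]c4ccc(-n5cnnc5)cc34)CC2)nc1` differs from compound 3 by ((pyridin-2-yl)amino)methyl in place of methyl(3-methylbut-2-en-1-yl)amino on a saturated ring carbon. Going by the values given here, the one step that touches this position, an 8.6-fold lower number from compound 1 to compound 3 (0.93 log units; beyond the scatter), shows that swapping the group on the amine nitrogen moves the number modestly. Compound 2, which also carries an aminomethyl group on the ring carbon, sits between compound 1 and compound 3. A modest weakening is therefore expected, a 6.0-fold higher number from compound 3 to compound 4 (0.78 log units; beyond the scatter), and compound 4 is estimated at 3 nM (range 0.8 nM to 12 nM) in this assay.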

Compound 4, half-maximal inhibitory concentration: 1.7 nM
Estimate against measurement, compound 4: 1.8-fold (0.25 log units) above; measured number inside the range.
By their numbers in this assay, from the lowest: compound 3; then compounds 2 and 4 (each within the scatter of the next); then compound 1.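

Going by these compounds alone, on the saturated ring carbon in this assay, ((pyridin-2-yl)amino)methyl, the first group here with an aromatic ring joined through an amine nitrogen, gives a 3.4-fold higher number from compound 3 to compound 4 (0.53 log units; beyond the scatter) and also a 2.5-fold lower number from compound 1 to compound 4 (0.40 log units; beyond the scatter). On the amine nitrogen of the aminomethyl group, pyridin-2-yl and 1-(4-acetamidophenyl)ethyl are not told apart, with a 1.1-fold higher number from compound 2 to compound 4 (0.05 log units; within the scatter). No measurement is available to explain these steps. The compounds shown leave open whether phenyl in place of pyridin-2-yl would keep the number. They also leave open what a methyl group on the amine nitrogen of compound 4 would do.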